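Sulfonamide nitrogen substituent: ethyl to cyclopropyl

A few compounds are considered here, and "the series" means these few. Any claim that something is new, unique, unknown or untested is made for them only; others in the source may bear on it.

Of the compounds shown here, two carry numbers so far. Compound 1 `CCN(C/C=C/C#CC(C)(C)C)Cc1cccc(OCCN(C)S(=O)(=O)c2cccs2)c1` gives, in a functional assay on HepG2 cells for inhibition of squalene monooxygenase (Homo sapiens) (on this read-out lower numbers stand for stronger inhibition and higher numbers for weaker inhibition), 60 nM. Compound 2 `CCN(C/C=C/C#CC(C)(C)C)Cc1cccc(OCCN(CC)S(=O)(=O)c2cccs2)c1` gives in this assay 90 nM, the highest of the two numbers, with compound 1 nearest to it; the step of a 1.5-fold higher number from compound 1 to compound 2 (0.18 log units; within the scatter) is within the scatter, so the two compounds cannot be ordered on these data.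

Compound 3 `CCN(C/C=C/C#CC(C)(C)C)Cc1cccc(OCCN(C2CC2)S(=O)(=O)c2cccs2)c1` is not yet measured. Its difference from compound 2 is cyclopropyl in place of ethyl on a sulfonamide nitrogen. Going by the values given here, the only measured step that bears on this position, a 1.5-fold higher number from compound 1 to compound 2 (0.18 log units; within the scatter), lies within the scatter and concerns the same substituent on the sulfonamide nitrogen; no other step touches this place, and no cyclopropyl has been measured anywhere in it. On this basis no step beyond the scatter is expected for compound 3 in this assay; the step of a 1.1-fold higher number from compound 2 to compound 3 (0.05 log units; within the scatter) is the expected shift, a small movement towards a higher number being as plausible as none at all. Compound 3 is accordingly estimated at 100 nM, with a range from 40 nM to 260 nM.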

Compound 3, half-maximal inhibitory concentration: 230 nM
Estimate against measurement, compound 3: 2.3-fold (0.36 log units) below, within the range that was stated.
By their numbers in this assay, from the lowest: compounds 1 and 2 (each within the scatter of the next); then compound 3.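

In this assay, the substituent on the sulfonamide nitrogen now makes a readable difference: a 2.6-fold higher number from compound 2 to compound 3 (0.41 log units; beyond the scatter) is beyond the scatter, whereas methyl and ethyl could not be ordered on the earlier data. The comparison with methyl points the same way, with a 3.8-fold higher number from compound 1 to compound 3 (0.58 log units; beyond the scatter), so among these three compounds cyclopropyl gives weaker inhibition than either of the two smaller chain substituents, which remain unresolved from each other. Nothing available here accounts for the weaker inhibition seen with cyclopropyl in place of ethyl.

From the compounds shown here alone, whether this change follows the three-membered ring as such or would also appear with other carbon substituents remains open, and isopropyl, propyl or cyclobutyl on this nitrogen would be the groups to separate those readings. Also open, going by these compounds, is whether a plain hydrogen on this nitrogen would stand with methyl and ethyl, and whether the step from ethyl to cyclopropyl would hold with a phenyl ring on the sulfonyl sulfur.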